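Pyrimidinyl for pyridinyl on the sulfonamide nitrogen

The source may hold more compounds than are shown below. What is called first, only, known or untested is meant among the compounds shown, and "the series" means these compounds.

Compound 2 `O=S(=O)(Nc1ccccn1)c1ccc(N/C(S)=N\c2ccnc3cc(C(F)(F)F)ccc23)cc1` gives 28000 nM in a functional assay on HT-1080 cells (Homo sapiens) for antiproliferative activity, read by sulforhodamine B assay, with a stated time of 48 h (on this read-out lower numbers stand for stronger inhibition and higher numbers for weaker inhibition), and compound 1 `NS(=O)(=O)c1ccc(N/C(S)=N\c2ccnc3cc(C(F)(F)F)ccc23)cc1` gives 31000 nM; the two numbers sit within the scatter of each other, as the step of a 1.1-fold lower number from compound 1 to compound 2 (0.04 log units; within the scatter) shows. Compound 3 `O=S(=O)(Nc1ncccn1)c1ccc(N/C(S)=N\c2ccnc3cc(C(F)(F)F)ccc23)cc1` carries the change (pyrimidin-2-yl in place of pyridin-2-yl on a sulfonamide nitrogen). Among the measured compounds shown here, the only measured step at this sulfonamide nitrogen, a 1.1-fold lower number from compound 1 to compound 2 (0.04 log units; within the scatter), stayed within the scatter, so no step beyond the scatter is expected here either, with no change at the digits printed from compound 2 to compound 3 (within the scatter) as the estimated step. Compound 3 is therefore expected to give about 28000 nM, with a range from 14000 nM to 56000 nM.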

Compound 3, half-maximal inhibitory concentration: 29100 nM
Estimate against measurement, compound 3: 1.0-fold (0.02 log units) below; the measured number falls inside the stated range.
By their numbers in this assay, from the lowest: compounds 2, 3 and 1 (each within the scatter of the next).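

In this assay, pyrimidin-2-yl in place of pyridin-2-yl gives a 1.0-fold higher number from compound 2 to compound 3 (0.02 log units; within the scatter) and pyrimidin-2-yl in place of hydrogen gives a 1.1-fold lower number from compound 1 to compound 3 (0.03 log units; within the scatter) at this sulfonamide nitrogen. Among the compounds shown here, two different aromatic rings and hydrogen now all lie within the scatter of one another at this place, where earlier only one ring could be set against hydrogen. No measured finding offers an explanation for this result. On these data alone, whether an acetyl or a methyl group on this nitrogen would give a step beyond the scatter remains open.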